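Fluoro for Methoxy on the Aryl Substituent

The compounds below may be only part of what the source reports. "The series", "measured", "known", "first", "only" and "open" are said of these compounds alone.

Measured compounds:
Compound 1, `CC(C)(C)OC(=O)N1CCN(CC(=O)Nc2ccc(C(=O)/C=C/c3cn(Cc4ccc(Br)cc4)nn3)cc2)CC1` — 38400 nM
Compound 2, `CCCCCCCCCCn1cc(/C=C/C(=O)c2ccc(NC(=O)CN3CCN(c4ccccc4F)CC3)cc2)nn1` — 57000 nM
Compound 3, `COc1ccccc1N1CCN(CC(=O)Nc2ccc(C(=O)/C=C/c3cn(Cc4ccc(Br)cc4)nn3)cc2)CC1` — 34000 nM

In a functional assay on A549 cells (Homo sapiens) for inhibition, read by MTT assay (a lower number here means a stronger inhibitor, a higher number a weaker inhibitor), compound 3 gives the lowest of the three numbers, but its gaps to compound 1 and to compound 2 both lie within the scatter, so no ordering among them can be read. Compound 4, `O=C(CN1CCN(c2ccccc2F)CC1)Nc1ccc(C(=O)/C=C/c2cn(Cc3ccc(Br)cc3)nn2)cc1`, differs from compound 3 by fluoro in place of methoxy on an aromatic carbon; the change sits on an aromatic carbon of a six-membered aromatic ring of carbon only, ortho to a large group.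

For the measured compounds named here, the one step that bears on this position is a 1.1-fold lower number from compound 1 to compound 3 (0.05 log units; within the scatter), where replacing tert-butoxycarbonyl with 2-methoxyphenyl on the amine nitrogen in the ring left this assay unchanged. Compound 2, which already carries a 2-fluorophenyl group at that nitrogen, gives a number in this assay that is also within the scatter of compound 3. The expectation is therefore a step of a 1.2-fold higher number from compound 3 to compound 4 (0.07 log units; within the scatter), nothing beyond the scatter in either direction. Compound 4 is estimated at 40000 nM, with a range from 18000 nM to 90000 nM.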

Compound 4, half-maximal inhibitory concentration: 14700 nM
The estimate for compound 4 lay 2.7-fold (0.43 log units) above the measured number, and the stated range ends above it.
By their numbers in this assay, from the lowest: compound 4; then compounds 3, 1 and 2 (each within the scatter of the next).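

Fluoro in place of methoxy on this aromatic carbon moves the number in this assay beyond the scatter (a 2.3-fold lower number from compound 3 to compound 4 (0.36 log units; beyond the scatter)), which shows that this position can respond, although the earlier step from tert-butoxycarbonyl to 2-methoxyphenyl on the ring amine nitrogen did not. The 2-fluorophenyl group also separates from tert-butoxycarbonyl at that nitrogen (a 2.6-fold lower number from compound 1 to compound 4 (0.42 log units; beyond the scatter)), which 2-methoxyphenyl did not do. With 2-fluorophenyl held constant, the other end of the molecule counts too, as 4-bromophenyl in place of nonyl gives a step beyond the scatter (a 3.9-fold lower number from compound 2 to compound 4 (0.59 log units; beyond the scatter)).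

Nothing given here explains any of these steps. On these data alone, whether chloro or methyl on the same aromatic carbon would behave like fluoro or like methoxy remains open.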